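From cyclopentyl to 4-methylphenyl on the amine nitrogen

A few compounds are considered here, and "the series" means these few. Any claim that something is new, unique, unknown or untested is made for them only; others in the source may bear on it.

Of the compounds shown here, three that share one core have been tested so far. In a functional assay on HeLa cells (Homo sapiens) for inhibition, read by sulforhodamine B assay (on this read-out lower numbers stand for stronger inhibition and higher numbers for weaker inhibition), compound 1 (`CCCc1ccc(NC2=CC(=O)c3nc4n(c3C2=O)[C@H]2OC[C@@H](O)[C@H]2OC4)cc1`) gives 4990 nM, and compound 2 (`O=C1C(Nc2ccccc2F)=CC(=O)c2c1nc1n2[C@H]2OC[C@@H](O)[C@H]2OC1`) gives 9820 nM, two values within the usual scatter of each other. Compound 3 (`O=C1C(NC2CCCC2)=CC(=O)c2c1nc1n2[C@H]2OC[C@@H](O)[C@H]2OC1`) gives > 16000 nM, which is a limit of the assay and not a number. Its true place on the scale is therefore unknown.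

Compound 4 (`Cc1ccc(NC2=CC(=O)c3c(nc4n3[C@H]3OC[C@@H](O)[C@H]3OC4)C2=O)cc1`) has not yet been measured. It carries 4-methylphenyl in place of the cyclopentyl of compound 3, on an amine nitrogen: 4-methylphenyl in place of cyclopentyl on an amine nitrogen.

Within the data shown here, only one measured step bears directly on this change, namely an at least 1.6-fold higher number from compound 2 to compound 3 (0.21 log units; that floor lies within the scatter). That step is small and its floor lies within the scatter, so it is weak evidence. The new change runs the other way, from cyclopentyl back to a phenyl group, so a move towards stronger inhibition in this assay is expected, though of uncertain size. The estimated step is an at least 2.2-fold lower number from compound 3 to compound 4 (0.35 log units; beyond the scatter). This expectation places the new compound near the values of the two compounds with phenyl groups, with compound 2 at 9820 nM as the closest guide. For compound 4 the expected value is 7000 nM, with an estimated range from 2800 nM to 16000 nM.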

Compound 4, half-maximal inhibitory concentration: 6590 nM
Compound 4: middle estimate off by 1.1-fold (0.03 log units), on the high side; measured number inside the range.
By their numbers in this assay, from the lowest: compounds 1, 4 and 2 (each within the scatter of the next). At a limit, above all of these: compound 3.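

In this assay, going from the cyclopentyl ring to 4-methylphenyl on this amine nitrogen gives an at least 2.4-fold lower number from compound 3 to compound 4 (0.38 log units; beyond the scatter). Among these compounds, this is the first change at this position that clears the scatter, since the floor of the earlier step from 2-fluorophenyl to cyclopentyl lay within it. The step is itself only a floor, since the reading for compound 3 is a limit of the assay and not a number: the limit of > 16000 nM in this assay, at which 1 of the 4 values shown sits.

Exchanging one substituted phenyl group for another does much less, giving a 1.5-fold lower number from compound 2 to compound 4 (0.17 log units; within the scatter), so 4-methylphenyl and 2-fluorophenyl cannot be told apart in this assay.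

Still open, on these data alone, is whether the split follows the aromatic ring or only sets cyclopentyl apart, and a plain phenyl, a pyridyl ring or an open chain such as butyl on the same nitrogen would help to decide that. As far as these compounds go, the compounds with a phenyl group all lie within the scatter of one another, so it also remains unknown whether any substituent on that ring, such as a methoxy group or a carboxylic acid, can move the number clearly in either direction.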